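Pyridin-3-yl replacing trifluoromethylphenyl where both anchors hit the limit

The compounds below may be only part of what the source reports. "The series", "measured", "known", "first", "only" and "open" are said of these compounds alone.

Measured compounds:
Compound 1 `Cc1ccc(-c2ccnc(Nc3ccc4c(c3)c(/C=C3/C(=O)Nc5ccccc53)cn4C)n2)cc1`: in a functional assay on LNCaP cells (Homo sapiens) for cytotoxicity, read by MTT assay, with a stated time of 48 h (on this read-out lower numbers stand for stronger inhibition and higher numbers for weaker inhibition), compound 1 reaches only the assay limit > 100000 nM.
Compound 2 `Cn1cc(/C=C2/C(=O)Nc3ccccc32)c2cc(Nc3nccc(-c4ccc(C(F)(F)F)cc4)n3)ccc21`: in this assay compound 2 reaches only the assay limit > 100000 nM.

Compound 2 thus stands at the limit of this assay, and that is all its number shows. Going by the values given here, the single measured step, a step that the two limits leave unreadable from compound 1 to compound 2, is unreadable for the same reason, and the whole of the evidence is the limit of > 100000 nM in this assay, at which 2 of the 2 values shown sit.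

Compound 3 `Cn1cc(/C=C2/C(=O)Nc3ccccc32)c2cc(Nc3nccc(-c4cccnc4)n3)ccc21` differs from compound 2 by pyridin-3-yl in place of 4-(trifluoromethyl)phenyl on an aromatic carbon. Among the compounds with values here, no measured step bears on this exchange; the one step recorded gives no size in either direction, so nothing points to a gain or a loss in this assay.

With both anchors at the limit, compound 3 is expected to sit near it, at an estimated 90000 nM with a range of 20000 nM to 300000 nM. The step this estimate implies, an at least 1.1-fold lower number from compound 2 to compound 3 (0.04 log units; that floor lies within the scatter), is expected to be unreadable rather than a shift beyond the scatter.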

Compound 3, half-maximal inhibitory concentration: 14200 nM
Beside the measured number, compound 3's estimate is 6.3-fold (0.80 log units) above it; measured number outside the range, below it.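

In this assay, the aromatic carbon next to the ring nitrogen now gives a readable change: pyridin-3-yl yields an at least 7.0-fold lower number from compound 2 to compound 3 (0.84 log units; beyond the scatter) and an at least 7.0-fold lower number from compound 1 to compound 3 (0.84 log units; beyond the scatter). The two carbon-only rings, 4-methylphenyl and 4-(trifluoromethyl)phenyl, therefore do not mark the only outcome at this position, and among the compounds shown only the pyridin-3-yl compound 3 comes inside the measurable range. Both steps are floors rather than full sizes: the limit of > 100000 nM in this assay, at which 2 of the 3 values shown sit.

On these data alone, whether the gain follows the ring nitrogen itself or the loss of the methyl and trifluoromethyl groups stays open, and the step between compound 1 and compound 2 cannot be read. An unsubstituted phenyl ring or a pyridin-2-yl at this position would bear on that question.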